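The source may hold more compounds than are shown below. What is called first, only, known or untested is meant among the compounds shown, and "the series" means these compounds.

Compound 1 `COc1ccc(/C=C\c2cc(OC)c(OC)c(OC)c2)cc1NC(=O)[C@H](CO)NC(=O)[C@H](CCCNC(=N)N)NC(=O)[C@H](CCCNC(=N)N)NC(=O)c1ccccc1` is built from a shared core carrying a short chain of amide-linked units, and in an ADME assay on HeLa cells (Homo sapiens) for cytotoxicity, with a stated time of 72 h (on this read-out higher numbers stand for lower toxicity in this test and lower numbers for higher toxicity in this test), compound 1 gives 29.2 nM. Compound 2 `COc1ccc(/C=C\c2cc(OC)c(OC)c(OC)c2)cc1NC(=O)[C@H](CO)NC(=O)[C@H](CCCNC(=N)N)NC(=O)[C@H](CCCCN)NC(=O)c1ccccc1` differs from it in one chain unit, and in this assay compound 2 gives 61.8 nM. Compound 3 `COc1ccc(/C=C\c2cc(OC)c(OC)c(OC)c2)cc1NC(=O)[C@H](C)N` keeps the core but carries only a single small amino-acid unit, and in this assay compound 3 gives 6.69 nM. Among these three numbers compound 2 stands highest, with a 2.1-fold higher number from compound 1 to compound 2 (0.33 log units; beyond the scatter) separating it from compound 1 and a wider gap to compound 3.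

Compound 4 `COc1ccc(/C=C\c2cc(OC)c(OC)c(OC)c2)cc1NC(=O)CNC(=O)[C@H](CCCNC(=N)N)NC(=O)[C@H](CCCCN)NC(=O)c1ccccc1` is the next step from compound 2: hydrogen in place of hydroxymethyl on a saturated chain carbon bound to an amide-type nitrogen and a carbonyl carbon. Among the compounds with values here, no measured step touches this position. Within the data shown here, the only measured step, from compound 1 to compound 2, concerns a different chain unit, and compound 3 differs from compound 2 in far more than one place, so neither tells how this change behaves. With nothing pointing either way, the expectation is a step no larger than the scatter: a 1.0-fold lower number from compound 2 to compound 4 (0.01 log units; within the scatter). Compound 4 is therefore estimated at 60 nM, with a range from 25 nM to 150 nM.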

Compound 4, half-maximal cytotoxic concentration: 78.2 nM
Compound 4: middle estimate off by 1.3-fold (0.12 log units), on the low side; the measured number falls inside the stated range.
By their numbers in this assay, from the lowest: compound 3; then compound 1; then compounds 2 and 4 (each within the scatter of the next).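

In this assay, putting hydrogen in place of hydroxymethyl on this saturated chain carbon gives a 1.3-fold higher number from compound 2 to compound 4 (0.10 log units; within the scatter) and so leaves compound 2 and compound 4 indistinguishable in this test. Within the data shown here, this is the first reading at this position, and it shows that the hydroxymethyl group, with the one hydrogen-bond donor and one hydrogen-bond acceptor counted for it, can be removed from this chain without a step that rises above the usual scatter of repeated measurements. The earlier step, a 2.1-fold higher number from compound 1 to compound 2 (0.33 log units; beyond the scatter) and made in a different chain unit, lies just beyond the scatter, so the change in one unit of this chain can register while the change at this position does not; no supporting measurement is available to explain this result.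

The compounds shown carry only hydroxymethyl or hydrogen on this carbon, so it remains open whether a methyl group, a benzyl group or a carboxylic acid there would give a step beyond the scatter. On these data alone, it also remains open whether removing hydroxymethyl would give a similarly small step in a chain whose other units differ, such as the chain of compound 1.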